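The compounds below may be only part of what the source reports. "The series", "measured", "known", "first", "only" and "open" are said of these compounds alone.

Of the compounds shown here, three built on one shared core have been tested in a functional assay on U-937 cells (Homo sapiens) for cytotoxicity, read by MTT assay, with a stated time of 48 h; on this read-out lower numbers stand for stronger inhibition and higher numbers for weaker inhibition. Compound 1 `COc1ccc(Nc2nc(-c3cccc(F)c3)nc3ccc(F)cc23)cc1` gives 41100 nM in this assay. For compound 2 `Fc1ccc(Nc2nc(-c3cccc(F)c3)nc3ccc(F)cc23)cc1` this assay reports only a limit, > 50000 nM. For compound 3 `Fc1cccc(-c2nc(Nc3ccccc3Cl)c3cc(F)ccc3n2)c1` this assay likewise reports only a limit, > 50000 nM. Given (the limit of > 50000 nM in this assay, at which 2 of the 3 values shown sit), compound 3 stands at the weak end of what the numbers can show. The step of an at least 1.2-fold higher number from compound 1 to compound 3 (0.08 log units; that floor lies within the scatter) therefore has only a floor, and the step that the two limits leave unreadable from compound 2 to compound 3 cannot be read at all.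

Compound 4 `Oc1cccc(Nc2nc(-c3cccc(F)c3)nc3ccc(F)cc23)c1` differs from compound 3 in one place: 3-hydroxyphenyl in place of 2-chlorophenyl on a nitrogen on an aromatic ring. The two measured steps that change the group on this nitrogen, an at least 1.2-fold higher number from compound 1 to compound 3 (0.08 log units; that floor lies within the scatter) and a step that the two limits leave unreadable from compound 2 to compound 3, are small or unreadable, and compound 1, carrying 4-methoxyphenyl on a nitrogen on an aromatic ring, gives 41100 nM. No step beyond the scatter is therefore expected, and the estimated step from compound 3 to compound 4, an at least 1.1-fold lower number from compound 3 to compound 4 (0.04 log units; that floor lies within the scatter), is barely readable because compound 3 itself sits at the limit described by the limit of > 50000 nM in this assay, at which 2 of the 3 values shown sit. Compound 4 is expected to give about 45000 nM, in a range from 20000 nM to 100000 nM.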

Compound 4, half-maximal inhibitory concentration: > 50000 nM
Compound 4 ended at the assay's limit; the forecaster's own chance of this, stated with the estimate: 55%; middle value at least 1.1-fold (0.04 log units) away from the limit.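

Swapping 2-chlorophenyl for 3-hydroxyphenyl on this nitrogen adds a hydrogen-bond donor, yet in this assay compound 4 reports only a limit, not a number. Within the data shown here, the one readable step is an at least 1.2-fold higher number from compound 1 to compound 4 (0.08 log units; that floor lies within the scatter), while the steps linking compound 4 to compound 2 and compound 3 cannot be read. Compound 1 remains the only one of the four with a number, and none of the groups shown on this nitrogen has yet given a step beyond the scatter: the limit of > 50000 nM in this assay, at which 3 of the 4 values shown sit.

Still open, going by these compounds, is whether any group on this nitrogen can give a number well clear of the limit, such as a phenyl ring bearing a carboxylic acid or a dimethylamino group, or a butyl chain in place of the ring. Compound 2, compound 3 and compound 4 also cannot be ordered among themselves.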